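Swapping a Hydroxy for a Methoxycarbonyl on the Chain

The compounds below may be only part of what the source reports. "The series", "measured", "known", "first", "only" and "open" are said of these compounds alone.

Compound 1 `CC[C@H](C)[C@@H](NC(=O)Cn1cc(C2=C(c3c[nH]c4ccccc34)C(=O)N(C)C2=O)c2ccccc21)C(=O)OC`: in a functional assay on HCT-8 cells (Homo sapiens) for cytotoxicity, read by MTT assay, with a stated time of 24 h (on this read-out higher numbers stand for weaker inhibition and lower numbers for stronger inhibition), compound 1 gives only the limit > 100000 nM.
Compound 2 `COC(=O)CCNC(=O)Cn1cc(C2=C(c3c[nH]c4ccccc34)C(=O)N(C)C2=O)c2ccccc21`: in this assay compound 2 gives 50900 nM.
Compound 3 `COC(=O)[C@@H](CO)NC(=O)Cn1cc(C2=C(c3c[nH]c4ccccc34)C(=O)N(C)C2=O)c2ccccc21`: in this assay compound 3 gives 22900 nM.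

Compound 3 holds the lowest of the two numbers; compound 2 is nearest, with a step of a 2.2-fold lower number from compound 2 to compound 3 (0.35 log units; beyond the scatter), while compound 1 sits at a limit (the limit of > 100000 nM in this assay, at which 1 of the 3 values shown sits). Compound 4 `COC(=O)C[C@@H](NC(=O)Cn1cc(C2=C(c3c[nH]c4ccccc34)C(=O)N(C)C2=O)c2ccccc21)C(=O)OC` differs from compound 3 by methoxycarbonyl in place of hydroxy on a saturated chain carbon, two bonds along the chain from an amide-type nitrogen and a carbonyl carbon.

Among the measured compounds shown here, two measured steps bear on this change. The step of a 2.2-fold lower number from compound 2 to compound 3 (0.35 log units; beyond the scatter) shows that bringing in the hydroxy group along with the methoxycarbonyl gave a modestly lower number. The step of an at least 4.3-fold lower number from compound 1 to compound 3 (0.64 log units; beyond the scatter) shows that hydroxymethyl in place of sec-butyl gave an at least modest lowering. Compound 4 removes that hydroxy and puts a second methoxycarbonyl in its place, so it is expected to drift back toward the number of compound 2, giving an expected step of a 1.7-fold higher number from compound 3 to compound 4 (0.24 log units; within the scatter). For compound 4 the expected value is 40000 nM, within a range of 15000 nM to 100000 nM.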

Compound 4, half-maximal inhibitory concentration: 23400 nM
Beside the measured number, compound 4's estimate is 1.7-fold (0.23 log units) above it; the measured number falls inside the stated range.
By their numbers in this assay, from the lowest: compounds 3 and 4 (each within the scatter of the next); then compound 2. At a limit, above all of these: compound 1.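

In this assay, the step of a 1.0-fold higher number from compound 3 to compound 4 (0.01 log units; within the scatter) shows that the lower number of compound 3 does not depend on its hydroxy, since a methoxycarbonyl on the same saturated chain carbon gives a value within the scatter. The step of a 2.2-fold lower number from compound 2 to compound 4 (0.34 log units; beyond the scatter) is modest and close in size to the step of a 2.2-fold lower number from compound 2 to compound 3 (0.35 log units; beyond the scatter), so two different chain ends give much the same gain over the shorter chain. The step of an at least 4.2-fold lower number from compound 1 to compound 4 (0.63 log units; beyond the scatter) gives only a floor, and compound 1 stands at a limit: the limit of > 100000 nM in this assay, at which 1 of the 4 values shown sits.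

From the compounds shown here alone, whether an amine, a carboxylic acid or a longer chain at this carbon would keep, lower or raise the number remains open. Also open, going by these compounds, is whether hydroxy and methoxycarbonyl match here for one shared reason or for separate ones.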